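Triazole and imidazole carboxamides on a shared hydroxylactam core

The source may hold more compounds than are shown below. What is called first, only, known or untested is meant among the compounds shown, and "the series" means these compounds.

Measured compounds:
- compound 1 `NC(=O)c1ncn(CCC2(O)NC(=O)C(OCc3ccccc3)=C2OCc2ccccc2)n1`: in a functional assay on MIA PaCa-2 cells (Homo sapiens) for antiproliferative activity, read by MTT assay, with a stated time of 72 h (on this read-out higher numbers stand for weaker inhibition and lower numbers for stronger inhibition), compound 1 gives > 100000 nM, which is a limit of the assay and not a number.
- compound 2 `COC(=O)c1ncn(CCC2(O)NC(=O)C(OCc3ccccc3)=C2OCc2ccccc2)c1C(=O)OC`: in this assay compound 2 gives 47000 nM.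
- compound 3 `COC(=O)c1ncn(C[C@H](O)[C@H]2OC(=O)C(OCc3ccccc3)=C2OCc2ccccc2)n1`: in this assay compound 3 gives > 100000 nM, again a limit of the assay.

Compound 1 stands at the limit of > 100000 nM in this assay, at which 2 of the 3 values shown sit, so no number is known for it. Compound 4 `NC(=O)c1ncn(CCC2(O)NC(=O)C(OCc3ccccc3)=C2OCc2ccccc2)c1C(N)=O` differs from compound 1 by 4,5-dicarbamoyl-1H-imidazol-1-yl in place of 3-carbamoyl-1H-1,2,4-triazol-1-yl on a saturated chain carbon, two bonds along the chain from a saturated ring carbon. Among the measured compounds shown here, no step between measured compounds bears on this change, and the starting point is a limit rather than a value. The step from compound 1 to compound 4 is therefore expected to be small, an at least 1.1-fold lower number from compound 1 to compound 4 (0.04 log units; that floor lies within the scatter), and not clearly beyond the scatter. Compound 4 is expected to give about 90000 nM in this assay, within 30000 nM to 250000 nM.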

Compound 4, half-maximal inhibitory concentration: > 100000 nM
Compound 4 was reported as a limit; the forecaster's own chance of this, stated with the estimate: 50%; at least 1.1-fold (0.04 log units) between middle value and limit.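

Compound 4, like compound 1, rests at a limit of the assay, so no step can be read between them: the limit of > 100000 nM in this assay, at which 3 of the 4 values shown sit.
Open remains whether 4,5-dicarbamoyl-1H-imidazol-1-yl in place of 3-carbamoyl-1H-1,2,4-triazol-1-yl changes the read-out at all.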